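The compounds below may be only part of what the source reports. "The series", "measured", "known", "first", "only" and "open" are said of these compounds alone.

Compound 1 `CC1=CC[C@H](C(C)(C)NC(=S)N/N=C/c2cccc(Cl)c2)CC1` gives > 100000 nM in a functional assay on K562 cells (Homo sapiens) for inhibition, read by sulforhodamine B assay, with a stated time of 48 h; a lower number here means a stronger inhibitor of growth, a higher number a weaker inhibitor of growth; this value is a limit of the assay, not a number.
Compound 2 `CC1=CC[C@H](C(C)(C)NC(=S)N/N=C(\C)c2ccccc2)CC1` gives > 100000 nM in this assay, again a limit.
Compound 3 `COc1ccc(/C(C)=N/NC(=S)NC(C)(C)[C@H]2CC=C(C)CC2)cc1` gives > 100000 nM in this assay, again a limit.

Among the measured compounds shown here, compound 3 therefore stands at the limit, like every other value measured so far: all three sit at the limit of > 100000 nM in this assay, at which 3 of the 3 values shown sit. For the measured compounds named here, the one single-point step among the measured compounds, a step that the two limits leave unreadable from compound 2 to compound 3, runs between two limits and cannot be read. Going by the values given here, no compound in the set has given a number.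

Compound 4 `CC1=CC[C@H](C(C)(C)NC(=S)N/N=C(\C)c2ccc([N+](=O)[O-])cc2)CC1` is the next member. Its change from compound 3 is nitro in place of methoxy on an aromatic carbon, in words nitro in place of methoxy on an aromatic carbon. Among the compounds with values here, no measured step covers a nitro group, and the only measured step on this aromatic ring, from compound 2 to compound 3, is unreadable. The change is expected to stay within the scatter, so the expected step is a number no higher from compound 3 to compound 4 (the limit leaves the size open). Compound 4 is estimated at 100000 nM in this assay, between 30000 nM and 300000 nM, most probably reported as a limit again.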

Compound 4, concentration for total growth inhibition: > 100000 nM
Compound 4: no number, only a limit (the forecaster's own chance of this, stated with the estimate: 80%); the middle value lies on the limit itself.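

The steps from compound 2 and from compound 3 to compound 4 cannot be read, as each runs between two limits: the limit of > 100000 nM in this assay, at which 4 of the 4 values shown sit.

The compounds shown leave open whether any change on the aromatic ring gives a number in this assay and how large such a step would be.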